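The source may hold more compounds than are shown below. What is called first, only, known or untested is meant among the compounds shown, and "the series" means these compounds.

Measured so far:
Compound 1, `O=C(O)c1ccc(-n2cccc2)cc1` — 535000 nM
Compound 2, `COC(=O)c1ccc(-c2noc(CSC#N)n2)cc1` — 43700 nM
Compound 3, `N#CSCc1nc(-c2ccc(C(=O)O)cc2)no1` — 383000 nM

In an ADME assay on MT2 cells (Homo sapiens) for cytotoxicity, read by XTT assay, with a stated time of 4 days (on this read-out lower numbers stand for higher toxicity in this test and higher numbers for lower toxicity in this test), compound 3 stands second highest of the three numbers. Its nearest neighbour is compound 1, whose 535000 nM lies within the scatter of compound 3, so the two cannot be ordered. For the measured compounds named here, compound 2 is furthest away: the one measured step, an 8.8-fold higher number from compound 2 to compound 3 (0.94 log units; beyond the scatter), separates it from compound 3.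

Compound 4, `O=C(O)c1ccc(-c2noc(C(F)(F)F)n2)cc1`, has not yet been measured. It differs from compound 3 in one place: trifluoromethyl in place of (cyanosulfanyl)methyl on an aromatic carbon. Going by the values given here, no measured step concerns a change at this aromatic carbon; the only step on record, an 8.8-fold higher number from compound 2 to compound 3 (0.94 log units; beyond the scatter), concerns the oxygen next to the carbonyl group, which compound 4 keeps as in compound 3. Both compounds that carry the free acid, compound 1 and compound 3, give the two high numbers. Compound 4 is therefore expected to stay near compound 3, with a step of a 1.0-fold higher number from compound 3 to compound 4 (0.02 log units; within the scatter) that is not expected to exceed the scatter. The estimate for compound 4 is 400000 nM, ranging from 150000 nM to 1000000 nM.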

Compound 4, half-maximal cytotoxic concentration: 82300 nM
Compound 4: middle estimate off by 4.9-fold (0.69 log units), on the high side; measured number outside the range, below it.
By their numbers in this assay, from the lowest: compounds 2 and 4 (each within the scatter of the next); then compounds 3 and 1 (each within the scatter of the next).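

In this assay, the aromatic carbon of the five-membered ring with 2 nitrogen and 1 oxygen proves to be a position where a change registers: trifluoromethyl in place of (cyanosulfanyl)methyl gives a 4.7-fold lower number from compound 3 to compound 4 (0.67 log units; beyond the scatter). The free acid, shared by compound 3 and compound 4, therefore does not keep the number high on its own, and a lower number does not require the (cyanosulfanyl)methyl group, which compound 4 lacks. Nothing available explains why this change lowers the number.

From the compounds shown here alone, it remains open whether other groups at this carbon, such as an amine or a longer carbon chain, would also lower the number. For the compounds shown here, it is equally open whether the change at the acid would be similar with trifluoromethyl present, as the only such step, an 8.8-fold higher number from compound 2 to compound 3 (0.94 log units; beyond the scatter), carries (cyanosulfanyl)methyl.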